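A few compounds are considered here, and "the series" means these few. Any claim that something is new, unique, unknown or untested is made for them only; others in the source may bear on it.

Measured so far in an assay on isolated protein (strain Charles River) for antagonist activity at histamine H2 receptor (Rattus norvegicus); on this read-out lower numbers stand for an effect already at smaller amounts and higher numbers for an effect only at larger amounts of compound:
- compound 1 `Cc1cc(C)c2ccc(=O)n(CCN(C)C)c2n1` gives 3.93 ug/mL
- compound 2 `COc1cc(C)c2ccc(=O)n(CCN(C)C)c2n1` gives 7.01 ug/mL
- compound 3 `Cc1nc2c(ccc(=O)n2CCN(C)C)c(C)c1C` gives 12.5 ug/mL

Compound 1 has the lowest number of the three. Its nearest neighbour is compound 2, reached by a 1.8-fold higher number from compound 1 to compound 2 (0.25 log units; within the scatter), a step that stays within the scatter. Further off is compound 3: a 3.2-fold higher number from compound 1 to compound 3 (0.50 log units; beyond the scatter), a modest step that does lie beyond the scatter. Both of these steps alter the aromatic part of the shared core, and neither touches the side chain.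

Compound 4 `Cc1cc(C)c2ccc(=O)n(CCN)c2n1` is the next compound to go into this assay. It differs from compound 1 as follows: amino in place of dimethylamino on a saturated chain carbon, two bonds along the chain from an aromatic nitrogen. Among the measured compounds shown here, no measured step in the set changes the side chain, so the two recorded steps give no direct guide to the direction or size of this change; they show only that compound 1 sits at the favourable end of a narrow spread.

With nothing in the data to anchor the change, the expectation for compound 4 is a step of about a 2.0-fold higher number from compound 1 to compound 4 (0.31 log units; beyond the scatter), leaning toward a somewhat higher number than compound 1 but with wide uncertainty in both directions. The estimate for compound 4 is therefore 8 ug/mL, with a range from 2.5 ug/mL to 25 ug/mL.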

Compound 4, half-maximal effective concentration: 33.8 ug/mL
Estimate against measurement, compound 4: 4.2-fold (0.63 log units) below; measured number outside the range, above it.
By their numbers in this assay, from the lowest: compounds 1, 2 and 3 (each within the scatter of the next, the first and the last beyond it); then compound 4.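

In this assay, the side chain turns out to be a position that responds to change: amino in place of dimethylamino gives an 8.6-fold higher number from compound 1 to compound 4 (0.93 log units; beyond the scatter) and is the largest step recorded so far. Among the compounds shown here, it leaves compound 1 with the lowest number of the four, and it shows that the 2-(dimethylamino)ethyl chain cannot be cut back to 2-aminoethyl without a shift beyond the scatter, whereas the earlier steps on the aromatic part of the shared core stayed smaller. The swap removes two carbon atoms and adds one hydrogen-bond donor in a single move, and nothing available separates these two differences or offers any explanation of the step.

As far as these compounds go, it remains open whether a methylamino group, carrying a single methyl, would read close to compound 1, close to compound 4 or in the gap between them, and how a diethylamino group, a pyrrolidine or a longer chain would read in this assay. Also open, from the compounds shown here alone, is whether the same swap from dimethylamino to amino would give a step of similar size on the cores of compound 2 and compound 3.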